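A Methyl Step Repeated on a Fluorinated Core

The source may hold more compounds than are shown below. What is called first, only, known or untested is meant among the compounds shown, and "the series" means these compounds.

Three compounds have been measured in a functional assay on A549 cells (Homo sapiens) for antiproliferative activity, read by MTT assay, with a stated time of 72 h; a lower number here means a stronger inhibitor, a higher number a weaker inhibitor:

Compound 1, `CC/C=C\C(=O)Nc1cc(Nc2nccc(-c3cn(C)c4ccccc34)n2)c(OC)cc1N(C)CCN(C)C`, gives 1530 nM.
Compound 2, `CC/C=C\C(=O)Nc1cc(Nc2nc(C)cc(-c3cn(C)c4ccccc34)n2)c(OC)cc1N(C)CCN(C)C`, gives 1090 nM.
Compound 3, `C=CC(=O)Nc1cc(Nc2nccc(-c3cn(C)c4ccc(F)cc34)n2)c(OC)cc1N(C)CCN(C)C`, gives 329 nM.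

Compound 1 and compound 2 differ in one place, (methyl in place of hydrogen on an aromatic carbon). This step gave a 1.4-fold lower number from compound 1 to compound 2 (0.15 log units; within the scatter), so the two cannot be ranked against each other. Compound 3 stands lowest of the three; its gaps to compound 2 and to compound 1 both lie beyond the scatter. How the core of compound 3 differs from the core of compound 1 is not broken down here.

Compound 4, `C=CC(=O)Nc1cc(Nc2nc(C)cc(-c3cn(C)c4ccc(F)cc34)n2)c(OC)cc1N(C)CCN(C)C`, has not yet been measured in this assay. It differs from compound 3 by methyl in place of hydrogen on an aromatic carbon. For the measured compounds named here, this is the same kind of change as the one from compound 1 to compound 2, though the surroundings are not identical: the carbon that takes the methyl is meta to a 5-fluoro-1-methyl-1H-indol-3-yl group in compound 4, whereas in compound 2 it is meta to a 1-methyl-1H-indol-3-yl group.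

Compound 4 is therefore expected to show a 1.3-fold lower number from compound 3 to compound 4 (0.10 log units; within the scatter), a step of about the size seen earlier, because the same kind of change produced a 1.4-fold lower number from compound 1 to compound 2 (0.15 log units; within the scatter). On that basis compound 4 is estimated at 260 nM. The likely range for compound 4 is estimated to run from 120 nM to 600 nM.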

Compound 4, half-maximal inhibitory concentration: 1490 nM
Compound 4: middle estimate off by 5.7-fold (0.76 log units), on the low side; measured number above the stated range.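

In this assay, the methyl that gave no readable change on the core of compound 1 is followed on the fluorinated core by a 4.5-fold higher number from compound 3 to compound 4 (0.66 log units; beyond the scatter). The change therefore did not carry over from one core to the other with the same effect, and the step on one core was a poor guide to the step on the other: the same change on two cores in this assay, a 1.4-fold lower number (0.15 log units; within the scatter) from compound 1 to compound 2 and a 4.5-fold higher number (0.66 log units; beyond the scatter) from compound 3 to compound 4, 6.4-fold (0.80 log units) apart, beyond the scatter of two such steps. This does not show why the two cores part ways: the two pairs differ from each other in more than one place, and two pairs cannot set a rule for the whole series.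

The compounds shown leave open whether the fluorine or the amide chain decides how the methyl step turns out, as no pair here changes either of them alone. They also leave open how the same carbon would respond to a larger or different group, such as an ethyl group or a primary amine.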